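The source may report more compounds than this note shows. Statements on the series, on what has been measured and on what is new or still open speak of the compounds shown alone.

Measured so far:
compound 1, `N#C/C(=C\c1c(-c2ccccc2)[nH]c2ccccc12)C(=O)c1ccccc1` — 16500 nM
compound 2, `COc1ccc(-c2[nH]c3ccc(OC)cc3c2C=C(C#N)C#N)cc1` — 14300 nM

In a functional assay on 786-0 cells (Homo sapiens) for inhibition, read by sulforhodamine B assay, with a stated time of 48 h (a higher number here means a weaker inhibitor of growth, a lower number a stronger inhibitor of growth), compound 1 gives 16500 nM and compound 2 gives 14300 nM; the two numbers lie within the usual scatter of each other, so neither can be called the stronger inhibitor. The unmeasured compound 3 is `N#C/C(=C\c1c(-c2ccccc2)[nH]c2ccccc12)S(=O)(=O)c1ccccc1`. It differs from compound 1 in one place: phenylsulfonyl in place of benzoyl on a double-bonded chain carbon bound to a double-bonded chain carbon and a triple-bonded carbon. Among the measured compounds shown here, with no measured step of this kind to draw on, the step from compound 1 to compound 3 is expected to be small, a 1.1-fold higher number from compound 1 to compound 3 (0.04 log units; within the scatter), not beyond the scatter in either direction. Compound 3 is therefore estimated to give 18000 nM in this assay, within a range of 6000 nM to 50000 nM.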

Compound 3, concentration for 50% growth inhibition: 9200 nM
Beside the measured number, compound 3's estimate is 2.0-fold (0.29 log units) above it; the range from low to high includes it.
By their numbers in this assay, from the lowest: compounds 3, 2 and 1 (each within the scatter of the next).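

In this assay, putting phenylsulfonyl in place of benzoyl on the double-bonded chain carbon gives a 1.8-fold lower number from compound 1 to compound 3 (0.25 log units; within the scatter). Among the compounds shown here, this is the first step measured at this place, and it shows that the two groups cannot be told apart here, so the benzoyl carbonyl is not needed to keep growth inhibition at this level in these cells. Nothing available bears on why this is so. Going by these compounds, whether a carboxylic acid, an ester or a primary amide on this carbon would fit the same picture remains open. So does whether a methyl on the sulfonyl in place of the phenyl would keep this level.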